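Fluoro replacing methoxy: from compound 2 to compound 3

The compounds below may be only part of what the source reports. "The series", "measured", "known", "first", "only" and "open" are said of these compounds alone.

The series is followed in an assay on isolated protein for binding affinity to 5-hydroxytryptamine receptor 1D (Homo sapiens); a lower number here means a stronger inhibitor, a higher number a weaker inhibitor. Compound 1 `Fc1ccc(-c2n[nH]cc2N2CCCNCC2)cc1` gives 2190 nM in this assay. Compound 2 `COc1cccc(-c2n[nH]cc2N2CCNCC2)c1` gives only a limit in this assay, > 10000 nM. That limit is shown by the limit of > 10000 nM in this assay, at which 1 of the 2 values shown sits. Compound 3 `Fc1cccc(-c2n[nH]cc2N2CCNCC2)c1` has not yet been measured in this assay. It differs from compound 2 by fluoro in place of methoxy on an aromatic carbon. Going by the values given here, no measured pair shows this change, so the size of the step cannot be read from the numbers, and the limit on compound 2 leaves both direction and size open. A fluoro on the aromatic ring is present in compound 1, whose value of 2190 nM lies within the measured window, but compound 1 and compound 3 differ in more than one place. Compound 3 is expected to sit near 6000 nM, between 1500 nM and 30000 nM. The expected step this estimate implies is an at least 1.6-fold lower number from compound 2 to compound 3 (0.22 log units; that floor lies within the scatter), with a real chance that only a limit is reported again.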

Compound 3, inhibition constant: 911 nM
Estimate against measurement, compound 3: 6.6-fold (0.82 log units) above, and the stated range ends above it.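

In this assay, fluoro in place of methoxy on an aromatic carbon meta to a large group gives an at least 10-fold lower number from compound 2 to compound 3 (1.04 log units; beyond the scatter), so the group at this position can shift the read-out well beyond the scatter. On these data alone, the full size of this step stays unknown, since one end of it is only a limit: the limit of > 10000 nM in this assay, at which 1 of the 3 values shown sits. Compound 3 gives 911 nM, which provides a measured reference for further changes at this position.

Chloro, nitrile or plain hydrogen at this carbon would show whether the difference follows from fluoro being present or from methoxy being absent. Going by these compounds alone, compound 1 and compound 3 differ in more than one place, so no step between them can be read, and the contribution of each difference remains open.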